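This account rests on a few compounds, and the source may have more. Where it says the series, first, only, none or still open, it means among the compounds named here.

Measured in a functional assay on WM 266-4 cells (Homo sapiens) for antiproliferative activity, read by MTT assay, with a stated time of 48 h; on this read-out higher numbers stand for weaker inhibition of growth and lower numbers for stronger inhibition of growth:
- Compound 1 `Fc1ccc(C2=NN(C(=S)Nc3ccccc3)C(c3ccc4c(c3)OCCO4)C2)cc1`: 22500 nM
- Compound 2 `S=C(Nc1ccccc1)N1N=C(c2ccc(Cl)cc2)CC1c1ccc2c(c1)OCCO2`: > 200000 nM, a limit and not a number
- Compound 3 `COc1ccccc1C1=NN(C(=S)Nc2ccccc2)C(c2ccc3c(c2)OCCO3)C1`: 25800 nM

Compound 3 lies within the scatter of compound 1, with a 1.1-fold higher number from compound 1 to compound 3 (0.06 log units; within the scatter). It stands clearly apart from compound 2, with an at least 7.7-fold lower number from compound 2 to compound 3 (0.88 log units; beyond the scatter).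

Compound 4 `S=C(Nc1ccccc1)N1N=C(c2ccc(Cl)c(Cl)c2)CC1c1ccc2c(c1)OCCO2` has 3,4-dichlorophenyl in place of 2-methoxyphenyl on a carbon with a double bond to nitrogen. The closest guide is compound 2, which carries 4-chlorophenyl and shows an at least 8.8-fold higher number from compound 1 to compound 2 (0.94 log units; beyond the scatter). Among the compounds with values here, a rise in this assay is therefore expected, although no measured compound carries the 3,4-dichlorophenyl group itself.

The expected change is a 2.7-fold higher number from compound 3 to compound 4 (0.43 log units; beyond the scatter). For compound 4 the estimate is 70000 nM, with an expected range of 18000 nM to 200000 nM.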

Compound 4, concentration for 50% growth inhibition: 58700 nM
Estimate against measurement, compound 4: 1.2-fold (0.08 log units) above; measured number inside the range.
By their numbers in this assay, from the lowest: compounds 1 and 3 (each within the scatter of the next); then compound 4. At a limit, above all of these: compound 2.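

In this assay, the added chloro on the aryl group lowers the number (an at least 3.4-fold lower number from compound 2 to compound 4 (0.53 log units; beyond the scatter)), so a chloro-bearing aryl group at this position need not stay out of measurable range. Compound 2 stands at a limit and not a number: the limit of > 200000 nM in this assay, at which 1 of the 4 values shown sits. The 3,4-dichlorophenyl group still does not match the earlier groups (a 2.3-fold higher number from compound 3 to compound 4 (0.36 log units; beyond the scatter); a 2.6-fold higher number from compound 1 to compound 4 (0.42 log units; beyond the scatter)).

Open, going by these compounds, is how a 3-chlorophenyl group alone would behave here. So is whether an amine or a carboxylic acid on this aryl ring would change the number.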